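Working notes on the sulfonyl aryl step to compound 4

A few compounds are considered here, and "the series" means these few. Any claim that something is new, unique, unknown or untested is made for them only; others in the source may bear on it.

Three compounds of the shared core have entries: compound 1 `COc1ccc(-c2cc(=O)c3c(OC)cc(OC)cc3n2C)cc1` without a sulfonyl, compound 2 `COC(=O)c1cc(=O)c2c(OC)cc(OC)cc2n1S(=O)(=O)c1ccc(C)cc1` and compound 3 `COc1ccc(-c2cc(=O)c3c(OC)cc(OC)cc3n2S(=O)(=O)c2cccc([N+](=O)[O-])c2)cc1` each with an aryl sulfonyl on the core nitrogen. In a functional assay on HepG2 cells (Homo sapiens) for antiproliferative activity, with a stated time of 72 h (on this read-out higher numbers stand for an effect only at larger amounts of compound and lower numbers for an effect already at smaller amounts), compound 1 has no result, "not determined" (no result reported). Compound 2 reached only a limit of this assay, > 20000 nM. Compound 3 likewise gave only a limit in this assay, > 39600 nM. Compound 3 therefore stands among the entries without a single number, at the limit of > 39600 nM in this assay, at which 1 of the 3 values shown sits, and the other sulfonyl entry sits at the limit of > 20000 nM in this assay, at which 1 of the 3 values shown sits. Within the data shown here, no step between measured compounds can be sized from these data.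

Compound 4 `COc1ccc(-c2cc(=O)c3c(OC)cc(OC)cc3n2S(=O)(=O)c2c(F)c(F)c(F)c(F)c2F)cc1` differs from compound 3 by 2,3,4,5,6-pentafluorophenyl in place of 3-nitrophenyl on a sulfonyl sulfur. With both sulfonyl compounds at limits, no direction for this change can be read from the series. In this assay the expected step is a step that the limit leaves unreadable from compound 3 to compound 4, none beyond the scatter. Compound 4 is expected to give about 40000 nM in this assay, within 10000 nM to 150000 nM, most likely again reported as a limit.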

Compound 4, half-maximal effective concentration: > 34400 nM
Compound 4: no number, only a limit (the forecaster's own chance of this, stated with the estimate: 75%); the middle value does not contradict the limit.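

Among these compounds, compound 3 and compound 4 both stand only at limits in this assay, so no step between them can be read. The compounds shown leave open whether 2,3,4,5,6-pentafluorophenyl and 3-nitrophenyl on a sulfonyl sulfur differ at all in this assay.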